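A few compounds are considered here, and "the series" means these few. Any claim that something is new, unique, unknown or untested is made for them only; others in the source may bear on it.

Compound 1, `Fc1ccc(CSc2nnc(-c3ccc4c(c3)OCCO4)o2)cc1`: in a functional assay on HepG2 cells (Homo sapiens) for antiproliferative activity, read by MTT assay, with a stated time of 48 h (a higher number here means a weaker inhibitor, a lower number a stronger inhibitor), compound 1 gives 38000 nM.
Compound 2, `Cc1ccc(CSc2nnc(-c3ccc4c(c3)OCCO4)o2)cc1`: compound 2 gives 41900 nM.
Compound 3, `Fc1ccccc1CSc1nnc(-c2ccc3c(c2)OCCO3)o1`: compound 3 gives 24000 nM.

Compound 3 has the lowest of the three numbers, yet the gaps to the others are small: a 1.6-fold lower number from compound 1 to compound 3 (0.20 log units; within the scatter) and a 1.7-fold lower number from compound 2 to compound 3 (0.24 log units; within the scatter) both sit within the scatter, so nothing separates compound 3 from compound 1 or compound 2 beyond the usual variation of repeat measurements. Compound 4, `Clc1ccc(CSc2nnc(-c3ccc4c(c3)OCCO4)o2)cc1`, has not yet been measured in this assay. It differs from compound 3 in one place: 4-chlorophenyl in place of 2-fluorophenyl on a saturated chain carbon bound to a sulfur. The steps that speak to this change are those that also exchange the group on that chain carbon, a 1.6-fold lower number from compound 1 to compound 3 (0.20 log units; within the scatter) and a 1.7-fold lower number from compound 2 to compound 3 (0.24 log units; within the scatter), and a 1.1-fold higher number from compound 1 to compound 2 (0.04 log units; within the scatter) shows that swapping methyl for fluoro on the aromatic carbon made no difference beyond the scatter either. Three different groups at this position gave numbers within the scatter of one another, so within this small set the position looks tolerant. For compound 4 the expected step is a 1.5-fold higher number from compound 3 to compound 4 (0.16 log units; within the scatter), within the scatter. Compound 4 is estimated at 35000 nM, with a range from 17000 nM to 70000 nM.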

Compound 4, half-maximal inhibitory concentration: 28800 nM
Estimate against measurement, compound 4: 1.2-fold (0.08 log units) above; the range from low to high includes it.
By their numbers in this assay, from the lowest: compounds 3, 4, 1 and 2 (each within the scatter of the next).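

Adding compound 4 gives the first chlorine-bearing group at this position: in this assay, 4-chlorophenyl in place of 2-fluorophenyl on the saturated chain carbon bound to a sulfur gives a 1.2-fold higher number from compound 3 to compound 4 (0.08 log units; within the scatter), so this exchange does not separate the two compounds. The new compound also allows a direct comparison on the same aromatic carbon: chloro in place of methyl gives a 1.5-fold lower number from compound 2 to compound 4 (0.16 log units; within the scatter), and chloro in place of fluoro gives a 1.3-fold lower number from compound 1 to compound 4 (0.12 log units; within the scatter), so chloro, fluoro and methyl cannot be told apart there. No further measurement is available to explain these results.

From the compounds shown here alone, it remains open whether this tolerance would hold with an amine or a carboxylic acid on the phenyl ring, or with a longer chain in place of the benzyl group. Going by these compounds, the shared core is also constant across all four compounds, so the effect of changing it remains unknown.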